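The compounds below may be only part of what the source reports. "The series", "measured", "known", "first", "only" and "open" are said of these compounds alone.

Compound 1 `Cc1ccc(/C=C2\CC[C@H]3C(C)(C)CCC[C@]3(C)[C@H]2CCC(C)CC(=O)O)cc1` — in an ADME assay on HUVEC cells (Homo sapiens) for cytotoxicity, read by MTT assay, with a stated time of 24 h (a lower number here means a stronger inhibitor, a higher number a weaker inhibitor), compound 1 gives > 200000 nM, which is a limit of the assay and not a number.
Compound 2 `CC(CC[C@H]1/C(=C/c2ccc(Cl)cc2)CC[C@H]2C(C)(C)CCC[C@]12C)CC(=O)O` — in this assay compound 2 gives > 200000 nM, again a limit of the assay rather than a number.

Compound 2 therefore stands at the top of what this assay can report, and it shares that position with compound 1, so neither can be placed above the other. Within the data shown here, the one step between them, a step that the two limits leave unreadable from compound 1 to compound 2, cannot be sized, since (the limit of > 200000 nM in this assay, at which 2 of the 2 values shown sit).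

Compound 3 `CC(CC[C@H]1/C(=C/c2ccc(Br)cc2)CC[C@H]2C(C)(C)CCC[C@]12C)CC(=O)O` differs from compound 2 by a single change: bromo in place of chloro on an aromatic carbon. Among the measured compounds shown here, the only measured step in this assay is unreadable, so no measured change bears on this swap in a way that can be sized. With compound 2 at the limit, compound 3 is expected to stay near that limit too, and the step that the limit leaves unreadable from compound 2 to compound 3 is expected to lie within the scatter. For compound 3 the estimate in this assay is 300000 nM, expected to fall between 100000 nM and 1000000 nM.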

Compound 3, half-maximal inhibitory concentration: > 200000 nM
Compound 3: no number, only a limit (the forecaster's own chance of this, stated with the estimate: 85%); the middle value lies beyond the limit too.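

Compound 3 also gives only a limit in this assay, not a number, so neither of its steps, from compound 1 or from compound 2, can be read: the limit of > 200000 nM in this assay, at which 3 of the 3 values shown sit.

The compounds shown leave open whether methyl, chloro and bromo differ at all in this assay.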